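This account rests on a few compounds, and the source may have more. Where it says the series, first, only, none or still open, it means among the compounds named here.

Measured compounds:
Compound 1, `CCOc1cccc(-c2ccc(CN(C(=O)C(C)C)c3cccc(/C=C/C(=O)OC)c3)cc2)c1`, gives 173 nM in an assay on isolated protein with Bile acid receptor (Homo sapiens) as the target; on this read-out lower numbers stand for an effect already at smaller amounts and higher numbers for an effect only at larger amounts of compound.
Compound 2, `COC(=O)/C=C/c1cccc(N(Cc2ccc(-c3cccc(C)c3)cc2)C(=O)C(C)C)c1`, gives 163 nM in this assay.

Compound 2 stands next to compound 1 on these numbers: the step of a 1.1-fold lower number from compound 1 to compound 2 (0.03 log units; within the scatter) lies within the scatter, so the two compounds cannot be told apart on this read-out. Compound 3, `COC(=O)/C=C/c1cccc(N(Cc2ccc(-c3cccc(OC)c3)cc2)C(=O)C(C)C)c1`, has not yet been measured. It differs from compound 2 in one place: methoxy in place of methyl on an aromatic carbon. For the measured compounds named here, the only measured step that bears on this change is the one from compound 1 to compound 2, where an ethoxy was exchanged for a methyl at the same aromatic carbon and the number moved by a 1.1-fold lower number from compound 1 to compound 2 (0.03 log units; within the scatter), a shift within the scatter. The change to compound 3 puts a methoxy at that carbon, a group that sits between ethoxy and methyl in what it carries. On this basis, compound 3 is expected to give a number close to that of compound 2, with the expected step of a 1.0-fold higher number from compound 2 to compound 3 (0.01 log units; within the scatter) staying within the scatter. The estimate for compound 3 is 165 nM, with a range from 80 nM to 330 nM.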

Compound 3, half-maximal effective concentration: 72 nM
Beside the measured number, compound 3's estimate is 2.3-fold (0.36 log units) above it; the whole stated range lies above it.
By their numbers in this assay, from the lowest: compound 3; then compounds 2 and 1 (each within the scatter of the next).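

At this aromatic carbon, the near-identical numbers for compound 1 and compound 2 could have suggested that the group there hardly matters in this assay, but methoxy separates from both, with a 2.3-fold lower number from compound 2 to compound 3 (0.35 log units; beyond the scatter) and a 2.4-fold lower number from compound 1 to compound 3 (0.38 log units; beyond the scatter), each modest but beyond the scatter. The oxygen alone does not account for the lower number, since compound 1 also has an oxygen at this carbon and stays within the scatter of compound 2; among these three compounds, the lowest number appears only with methoxy, and removing the end carbon of the ethoxy is enough to reach it. The data offer no measured explanation for why methoxy stands apart here.

On these data alone, it remains open how a hydroxyl, a fluorine or a longer chain such as propoxy would read at this same carbon, and whether a plain hydrogen there would give a number nearer compound 2 or compound 3. As far as these compounds go, it is also open whether the gain from methoxy would persist if a carboxylic acid replaced the methyl ester elsewhere in the shared core.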